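A few compounds are considered here, and "the series" means these few. Any claim that something is new, unique, unknown or untested is made for them only; others in the source may bear on it.

Compound 1 `c1ccc(-c2ccc(Cn3cncc3CNc3ccc(-c4ccccc4)c(-c4ccccc4)c3)cc2)cc1` was examined in a toxicity assay on NIH3T3 cells (Mus musculus) for cytotoxicity, read by resazurin assay; on this read-out lower numbers stand for an effect already at smaller amounts and higher numbers for an effect only at larger amounts of compound. In this assay compound 1 gives > 10000 nM, which is a limit of the assay rather than a number. Among the two values recorded for this assay, compound 1 sits at the limit of > 10000 nM in this assay, at which 1 of the 2 values shown sits. Compound 2 `CC(C)c1ccc(Cn2cncc2CNc2ccc(-c3nc4ccccc4s3)c(-c3ccccc3)c2)cc1` was also tested in this assay, and compound 2 gives > 1000 nM, again a limit rather than a number, sitting at the limit of > 1000 nM in this assay, at which 1 of the 2 values shown sits. Within the data shown here, no step between two measured compounds is available, so nothing about how a change in structure moves this read-out can be taken from the measured pair. Compound 3 `c1ccc(-c2ccc(Cn3cncc3CNc3ccc(-c4nc5ccccc5o4)c(-c4ccccc4)c3)cc2)cc1` is not yet measured. It differs from compound 1 by 1,3-benzoxazol-2-yl in place of phenyl on an aromatic carbon. Both recorded values are limits. The step expected here, a step that the limit leaves unreadable from compound 1 to compound 3, is none beyond the scatter. Compound 3 is expected to give 15000 nM in this assay, with a range from 5000 nM to 50000 nM, most likely again reported as a limit.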

Compound 3, half-maximal effective concentration: > 10000 nM
Compound 3: no number, only a limit; the forecaster's own chance of this, stated with the estimate: 80%; the middle value does not contradict the limit.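

In this assay compound 3 gives > 10000 nM, which is a limit and not a number. Among these compounds, compound 1 also stands at a limit, and no step between compound 1 and compound 3 can be read. The compounds shown leave open whether 1,3-benzoxazol-2-yl in place of phenyl changes the concentration at which toxicity appears in this assay.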